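A few compounds are considered here, and "the series" means these few. Any claim that something is new, unique, unknown or untested is made for them only; others in the source may bear on it.

Working notes on the series. In an ADME assay on cells for inhibition of anoctamin-2 (Homo sapiens), read by fluorescence, with a stated time of 20 min (on this read-out lower numbers stand for stronger inhibition and higher numbers for weaker inhibition), compound 1 `Cc1cc(Cl)ccc1OCc1nnc(-c2cccc(F)c2)o1` gives > 100000 nM, which is a limit of the assay and not a number. Compound 2 `Cc1cc(Cl)ccc1OC(F)(F)C(=O)N/N=C/c1ccccc1OC(F)(F)F` likewise gives > 100000 nM, again a limit. Compound 3 `COc1cccc(-c2nnc(COc3ccc(Cl)cc3C)o2)c1` gives > 100000 nM, also a limit. Compound 3 therefore stands at the limit, where every value shown here sits: the limit of > 100000 nM in this assay, at which 3 of the 3 values shown sit. Compound 4 `Cc1cc(Cl)ccc1OCc1nnc(-c2cccc(OC(F)(F)F)c2)o1` differs from compound 3 by trifluoromethyl in place of methyl on an oxygen on an aromatic ring. Going by the values given here, the only measured step, a step that the two limits leave unreadable from compound 1 to compound 3, cannot be read from its two limits and concerns another position, so no step size follows from it. For compound 4 the estimate is 100000 nM, with a range from 30000 nM to 300000 nM, a step of a number no higher from compound 3 to compound 4 (the limit leaves the size open) that is expected to stay within the scatter, most likely as a further limit.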

Compound 4, half-maximal inhibitory concentration: "not active" (no number reported)
Nothing numeric was reported for compound 4; the estimate stays without a comparison.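

No new step can be read from compound 3 to compound 4, since compound 4 carries no number. Whether methoxy to trifluoromethoxy shifts inhibition stays open, with most values shown at one limit: the limit of > 100000 nM in this assay, at which 3 of the 4 values shown sit.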